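Switching the aromatic arm of compound 2 for an isobutyl chain

The source may report more compounds than this note shows. Statements on the series, on what has been measured and on what is new or still open speak of the compounds shown alone.

Three compounds of the series have a number in an assay on isolated protein for inhibition of aldehyde dehydrogenase 1A1 (Homo sapiens), read by spectrophotometry, tested at 10 uM; on this read-out lower numbers stand for less inhibition and higher numbers for more inhibition at the one concentration tested (going by the name of the read-out). Compound 1 `Cc1cccc(Cn2c(OC3CCN(C(=O)c4ccco4)CC3)nc3ccccc32)c1` gives 68.3%. Compound 3 `Cc1cccc(Cn2c(CN3CCN(C(=O)CC(C)C)CC3)nc3ccccc32)c1` gives 71.4%. Compound 2 `O=C(C1CC1)N1CCN(Cc2nc3ccccc3n2Cc2ccccc2C(F)(F)F)CC1` gives 56.3%, the lowest of the three numbers; its gap to compound 1 and its larger gap to compound 3 both lie beyond the usual scatter of repeated measurements, so the inhibition of compound 2 in this assay is lower than that of the other two measured compounds.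

Compound 4 `CC(C)CCn1c(CN2CCN(C(=O)C3CC3)CC2)nc2ccccc21` has not yet been measured. It differs from compound 2 in one place: isobutyl in place of 2-(trifluoromethyl)phenyl on a saturated chain carbon bound to an aromatic nitrogen. Among the compounds with values here, no pair of measured compounds shows this kind of exchange, so the size of the step cannot be read off any measured pair, and the three numbers to hand all come from compounds carrying an aromatic group on that chain carbon.

The expectation for the step from compound 2 to compound 4 is a number 8.3 percentage points lower from compound 2 to compound 4 (within the scatter), a modest drop in inhibition that may well stay within the scatter. The estimated value for compound 4 in this assay is 48%, with a range from 25% to 70% that allows for the gap in the data.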

Compound 4, a percentage reported as inhibition, at one concentration (the size of the read-out at that concentration, not a potency): 70%
For compound 4 the middle estimate is 22 percentage points below the measured one; measured number inside the range.
By their numbers in this assay, from the lowest: compound 2; then compounds 1, 4 and 3 (each within the scatter of the next).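

Putting isobutyl in place of 2-(trifluoromethyl)phenyl on a saturated chain carbon bound to an aromatic nitrogen gives a number 13.7 percentage points higher from compound 2 to compound 4 (beyond the scatter) in this assay. Within the data shown here, this is the first reading at this position without an aromatic group, and it shows that an aromatic ring is not needed there for inhibition at the one concentration tested, at least with the rest of compound 4 in place. The exchange also removes the ring and the fluorine together, going from 10 heavy atoms to 4 heavy atoms, and no measurement at hand bears on the reason for the rise.

On these data alone, since the ring and the trifluoromethyl leave in a single step, their separate shares stay open; an unsubstituted phenyl or a cyclohexyl at the same place would begin to pull them apart. As far as these compounds go, this reading also comes from one pair at one concentration, so it remains open whether isobutyl or a longer chain at this position would give a similar step with the other amide groups of the series.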